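Notes on removing the chloro from compound 3

The compounds below may be only part of what the source reports. "The series", "measured", "known", "first", "only" and "open" are said of these compounds alone.

Compound 1, `COc1cc2c(Oc3ccc(NC(=O)c4cc(-c5ccccc5)nc5ccccc45)cc3F)ccnc2cc1OCCCN1CCCCC1`, in a functional assay on HT-29 cells (Homo sapiens) for cytotoxicity, read by MTT assay, with a stated time of 72 h (a lower number here means a stronger inhibitor, a higher number a weaker inhibitor), gives 530 nM.
Compound 2, `COc1cc2c(Oc3ccc(NC(=O)c4cc(-c5cccc(Cl)c5)nc5ccccc45)cc3F)ccnc2cc1OCCCN1CCCCC1`, in this assay gives 62 nM.
Compound 3, `COc1cc2c(Oc3ccc(NC(=O)c4cc(-c5cccc(Cl)c5)nc5ccccc45)cc3F)ccnc2cc1OCCCN1CCC(C)CC1`, in this assay gives 100 nM.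

Compound 3 has the second highest number of the three. Its nearest neighbour is compound 2: the step of a 1.6-fold higher number from compound 2 to compound 3 (0.21 log units; within the scatter) lies within the scatter, so the two are not separated. Compound 1 sits further off with the highest number, and its gap to compound 3 is beyond the scatter.

Compound 4, `COc1cc2c(Oc3ccc(NC(=O)c4cc(-c5ccccc5)nc5ccccc45)cc3F)ccnc2cc1OCCCN1CCC(C)CC1`, differs from compound 3 by hydrogen in place of chloro on an aromatic carbon. Among the measured compounds shown here, the one measured step that bears on this is an 8.5-fold lower number from compound 1 to compound 2 (0.93 log units; beyond the scatter), the same change run the other way, on compounds without the methyl on the saturated ring. Reversing it on compound 3 is expected to give an 8.5-fold higher number from compound 3 to compound 4 (0.93 log units; beyond the scatter), a clearly weaker inhibitor. The expected value for compound 4 in this assay is 850 nM, with a range from 300 nM to 2500 nM.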

Compound 4, half-maximal inhibitory concentration: 120 nM
Compound 4: the middle estimate sits 7.1-fold (0.85 log units) above what was measured; measured number below the stated range.
By their numbers in this assay, from the lowest: compounds 2, 3 and 4 (each within the scatter of the next); then compound 1.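

The chloro on the aromatic carbon carries no fixed contribution in this assay: with the methyl on the saturated ring present, the change to hydrogen gives a 1.2-fold higher number from compound 3 to compound 4 (0.08 log units; within the scatter), so the two cores respond differently to it: the same change on two cores in this assay, an 8.5-fold lower number (0.93 log units; beyond the scatter) from compound 1 to compound 2 and a 1.2-fold lower number (0.08 log units; within the scatter) from compound 4 to compound 3, 7.1-fold (0.85 log units) apart, beyond the scatter of two such steps

The methyl also depends on its partner, with a 4.4-fold lower number from compound 1 to compound 4 (0.65 log units; beyond the scatter) where the chloro is absent, although it does not separate compound 2 from compound 3: the same change on two cores in this assay, a 1.6-fold higher number (0.21 log units; within the scatter) from compound 2 to compound 3 and a 4.4-fold lower number (0.65 log units; beyond the scatter) from compound 1 to compound 4, 7.1-fold (0.85 log units) apart, beyond the scatter of two such steps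

In these four compounds, either group alone gives a step from compound 1 that lies beyond the scatter, and adding the second gives a step within it.

On these data alone, whether this holds for other groups on that aromatic carbon, such as an amine or a carboxylic acid, stays open. So does whether a longer chain on the saturated ring behaves as the methyl does.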